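This account rests on a few compounds, and the source may have more. Where it says the series, first, only, none or still open, it means among the compounds named here.

In a functional assay on PC-3 cells (Homo sapiens) for antiproliferative activity, read by MTT assay, with a stated time of 48 h (on this read-out lower numbers stand for stronger inhibition and higher numbers for weaker inhibition), compound 2 `COc1ccc(-c2nnc(-c3cn4ccccc4n3)o2)cc1` gives 13400 nM, the lower of the two numbers in the series, and compound 1 `Clc1ccc(-c2nnc(-c3cn4ccccc4n3)o2)cc1` gives 33700 nM. Compound 3 `Brc1ccc(-c2nnc(-c3cn4ccccc4n3)o2)cc1` reaches only a limit, > 50000 nM.

Compound 4 `COc1ccc(-c2nnc(-c3cn4cccc(C)c4n3)o2)cc1` carries methyl in place of hydrogen on an aromatic carbon of the six-membered aromatic ring with 1 nitrogen, two atoms from the ring nitrogen. The measured steps, a 2.5-fold lower number from compound 1 to compound 2 (0.40 log units; beyond the scatter), an at least 1.4-fold higher number from compound 1 to compound 3 (0.17 log units; that floor lies within the scatter) and an at least 3.7-fold higher number from compound 2 to compound 3 (0.57 log units; beyond the scatter), all exchange a different substituent at another place, so none tests this change directly. No firm direction follows from them, and a step within the scatter is expected, estimated as a 1.0-fold higher number from compound 2 to compound 4 (0.02 log units; within the scatter). Compound 4 is estimated at 14000 nM, with an expected range of 5500 nM to 40000 nM.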

Compound 4, half-maximal inhibitory concentration: 11800 nM
For compound 4 the middle estimate is 1.2-fold (0.07 log units) above the measured one, and the stated range covers the measured number.
By their numbers in this assay, from the lowest: compounds 4 and 2 (each within the scatter of the next); then compound 1. At a limit, above all of these: compound 3.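

In this assay, methyl in place of hydrogen on an aromatic carbon, two atoms from the ring nitrogen, gives a 1.1-fold lower number from compound 2 to compound 4 (0.06 log units; within the scatter), so this position accepts methyl without a change beyond the scatter. This is the first change shown away from the place of the chloro, methoxy and bromo exchanges. Nothing at hand bears on why this step is so small. Still open, on these data alone, is whether a longer chain, an amine or a carboxylic acid at this position would shift the number, and whether methyl here gives the same result with chloro in place of methoxy.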